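The source may hold more compounds than are shown below. What is called first, only, known or untested is meant among the compounds shown, and "the series" means these compounds.

Of the compounds shown here, two have so far been measured in a functional assay on MCF7 cells (Homo sapiens) for inhibition; a lower number here means a stronger inhibitor, a higher number a weaker inhibitor. There, compound 1 (`O=C(/C=C/c1ccc(B(O)O)cc1)c1ccc[nH]1`) gives 19000 nM, while compound 2 (`O=C(/C=C/c1ccc(I)cc1)c1ccc(O)cc1`) gives 7000 nM. Compound 2 therefore holds the lower of the two numbers and is the stronger inhibitor, with a gap to compound 1 that lies beyond the usual scatter.

The next compound, compound 3 (`O=C(/C=C/c1ccc(I)cc1)c1ccc(B(O)O)cc1`), departs from compound 2 at one place: a group of 3 heavy atoms (1 boron, 2 oxygen; no ring) in place of one oxygen atom, on an aromatic carbon. The hydroxy leaves an aromatic carbon, para to a large group, and a group containing boron and oxygen takes its place. Among the measured compounds shown here, no measured pair isolates this exchange. Compound 1 also carries a boron-containing group and stands at 19000 nM, but it differs from compound 2 in more than one place, so it gives no direct measure. In this assay, only a small shift toward a lower number is therefore expected, with no step beyond the scatter. The estimated step is a 1.4-fold lower number from compound 2 to compound 3 (0.15 log units; within the scatter). For compound 3 the expected value is 5000 nM, with an estimated range from 1500 nM to 18000 nM.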

Compound 3, half-maximal inhibitory concentration: 7000 nM
Beside the measured number, compound 3's estimate is 1.4-fold (0.15 log units) below it, and the stated range covers the measured number.
By their numbers in this assay, from the lowest: compounds 2 and 3 (each within the scatter of the next); then compound 1.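

In this assay, among the compounds shown here, replacing the hydroxy with the group of boron and oxygen, on an aromatic carbon para to a large group, gives no change at the digits printed from compound 2 to compound 3 (within the scatter), the first direct reading of this exchange. At this position on the shared core of compound 2 and compound 3, a group of 3 heavy atoms can therefore stand in place of one oxygen atom with no step beyond the scatter. Nothing shown here explains why the two groups give matching numbers.

From the compounds shown here alone, whether an amine, a methoxy group or a carboxylic acid at the same aromatic carbon would also stay within the scatter of these two compounds in this assay remains open. Going by these compounds, it is also open whether the same exchange would leave the number unchanged on a different core, such as that of compound 1, so this single step cannot yet be read as a general rule for the hydroxy and the boron-containing group.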